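Swapping the Pyrazine of Compound 2 for a Fluoropyridine

A few compounds are considered here, and "the series" means these few. Any claim that something is new, unique, unknown or untested is made for them only; others in the source may bear on it.

Compound 1: `CCC(C)(C)Cc1c[nH]c(CCc2ccc(-c3csnn3)cc2)n1`, 11 nM
Compound 2: `CCC(C)(C)Cc1c[nH]c(CCc2ccc(-c3cnccn3)cc2)n1`, 11 nM
Compound 3: `CCC(C)(C)Cc1c[nH]c(CCc2ccc(-n3cccn3)cc2)n1`, 9 nM

In a functional assay on HEK293 cells for agonist activity at Bombesin receptor subtype-3 (Mus musculus), read by luminescence and calcium flux, with a stated time of 10 min (on this read-out higher numbers stand for an effect only at larger amounts of compound and lower numbers for an effect already at smaller amounts), compound 2 gives 11 nM, level with compound 1 at the digits shown; together these are the highest of the three numbers. The nearest neighbour of compound 2 is compound 1, with no change at the digits printed from compound 1 to compound 2 (within the scatter), and the furthest is compound 3, with a 1.2-fold lower number from compound 2 to compound 3 (0.09 log units; within the scatter). Compound 1 and compound 3 are separated by a 1.2-fold lower number from compound 1 to compound 3 (0.09 log units; within the scatter). All three compounds share one core and differ only in the aromatic group on an aromatic carbon of the six-membered aromatic ring of carbon only.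

Compound 4, `CCC(C)(C)Cc1c[nH]c(CCc2ccc(-c3ccc(F)cn3)cc2)n1`, continues this series at the same place: 5-fluoropyridin-2-yl in place of pyrazin-2-yl on an aromatic carbon. The three measured steps all bear on it, since each exchanges one aromatic group for another at that position, and every one of them stayed within the scatter. Nothing in the measured set points to a direction for this change, so no step beyond the scatter is expected in this assay.

Compound 4 is therefore estimated at 11 nM, in a range of 5 nM to 25 nM. This corresponds to an expected step of no change at the digits printed from compound 2 to compound 4 (within the scatter).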

Compound 4, half-maximal effective concentration: 16 nM
Estimate against measurement, compound 4: 1.5-fold (0.16 log units) below; the range from low to high includes it.
By their numbers in this assay, from the lowest: compounds 3, 1, 2 and 4 (each within the scatter of the next).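

Among the compounds shown here, compound 4 is the first of the series in which the aromatic group carries a substituent of its own, and in this assay this fluorine-bearing group stays within the scatter of all three earlier groups (from the pyrazine, a 1.5-fold higher number from compound 2 to compound 4 (0.16 log units; within the scatter); from the thiadiazole, a 1.5-fold higher number from compound 1 to compound 4 (0.16 log units; within the scatter); from the pyrazole, a 1.8-fold higher number from compound 3 to compound 4 (0.25 log units; within the scatter)). The exchange also goes from 6 to 7 heavy atoms and from 2 hydrogen-bond acceptors to 1, so this place on the ring of carbon only, para to a large group, accepts both changes together without a step beyond the scatter. Nothing available explains why the read-out stays so flat across these groups.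

The step from compound 2 to compound 4 changes the ring nitrogen and the fluorine at once, so the compounds shown cannot separate the two, which a plain pyridin-2-yl group would do. All four compounds also carry an aromatic group at this place, leaving open whether a carboxylic acid, an amine or a saturated morpholine ring there would stay level with them.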